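Taking the phenyl off compound 3

This account rests on a few compounds, and the source may have more. Where it says the series, first, only, none or still open, it means among the compounds named here.

For the measured compounds named here, in a functional assay on K562 cells (Homo sapiens) for antiproliferative activity, read by MTT assay, with a stated time of 48 h (on this read-out higher numbers stand for weaker inhibition and lower numbers for stronger inhibition), compound 3 `Cn1cc(C2=C(c3nn(CCCn4ccnc4)c4ncccc34)C(=O)N(c3ccccc3)C2=O)c2ccccc21` gives 5510 nM, the lowest number so far. Compound 2 `Cn1cc(C2=C(c3nn(CCCn4cccc4)c4ncccc34)C(=O)NC2=O)c2ccccc21` gives 21600 nM. Compound 1 `Cn1cc(C2=C(c3nn(CCCn4cncn4)c4ncccc34)C(=O)NC2=O)c2ccccc21` reads > 100000 nM, which is a limit of the assay and not a number. Compound 4 `Cn1cc(C2=C(c3nn(CCCn4ccnc4)c4ncccc34)C(=O)NC2=O)c2ccccc21` has hydrogen in place of phenyl on an amide-type nitrogen in a ring. Going by the values given here, the one measured step, an at least 4.6-fold lower number from compound 1 to compound 2 (0.66 log units; beyond the scatter), changes a different group and leaves this nitrogen alone, so it gives only a sense of scale. Compound 2 already carries that hydrogen and sits at 21600 nM, so a modestly higher number is expected. The expected step is a 2.9-fold higher number from compound 3 to compound 4 (0.46 log units; beyond the scatter). Compound 4 is estimated at 16000 nM, with an expected range of 4500 nM to 60000 nM.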

Compound 4, half-maximal inhibitory concentration: 13800 nM
For compound 4 the middle estimate is 1.2-fold (0.06 log units) above the measured one; the measured number falls inside the stated range.
By their numbers in this assay, from the lowest: compound 3; then compounds 4 and 2 (each within the scatter of the next). At a limit, above all of these: compound 1.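

In this assay, for the compounds shown here, taking the phenyl off the amide-type nitrogen gives a 2.5-fold higher number from compound 3 to compound 4 (0.40 log units; beyond the scatter) and so shows for the first time that this position affects the number, with phenyl the lower of the two. Putting 1H-imidazol-1-yl in place of 1H-pyrrol-1-yl gives a 1.6-fold lower number from compound 2 to compound 4 (0.19 log units; within the scatter) and so no change that can be told apart from the scatter. Putting it in place of 1H-1,2,4-triazol-1-yl gives an at least 7.2-fold lower number from compound 1 to compound 4 (0.86 log units; beyond the scatter) and this step rests on a limit and not a number: the limit of > 100000 nM in this assay, at which 1 of the 4 values shown sits.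

Still open, on these data alone, is whether a methyl or a benzyl group on this nitrogen would read closer to phenyl or to hydrogen. Also open, as far as these compounds go, is whether an amine at the end of the chain would match the 1H-imidazol-1-yl group.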